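From pyridin-4-yl to 1H-indol-6-yl on a shared core

This account rests on a few compounds, and the source may have more. Where it says the series, first, only, none or still open, it means among the compounds named here.

Compound 1 `CC(C)N(Cc1cccc(OCCCCCC(=O)O)c1)C(=O)c1ccc(-c2ccncc2)cc1` was tested in an ADME assay on BJ cells (Homo sapiens) for cytotoxicity, read by CellTiter-Glo and resazurin assay, with a stated time of 72 h; on this read-out higher numbers stand for an effect only at larger amounts of compound and lower numbers for an effect already at smaller amounts. In this assay compound 1 gives > 26000 nM, which is a limit of the assay and not a number. Compound 2 `CC(C)COc1cccc(-c2ccc(C(=O)N(Cc3cccc(OCCCCCC(=O)O)c3)C(C)C)cc2)c1` was tested in the same way. In this assay compound 2 gives > 26000 nM, again only a limit. The change a step that the two limits leave unreadable from compound 1 to compound 2 therefore has no readable size, and the limit of > 26000 nM in this assay, at which 2 of the 2 values shown sit, is all that the two results offer.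

Compound 3 `CC(C)N(Cc1cccc(OCCCCCC(=O)O)c1)C(=O)c1ccc(-c2ccc3cc[nH]c3c2)cc1` has not yet been measured in this assay. It differs from compound 1 by 1H-indol-6-yl in place of pyridin-4-yl on an aromatic carbon. Going by the values given here, no measured step bears on this change in a readable way; both known values stop at the same limit. The expected step is a number no higher from compound 1 to compound 3 (the limit leaves the size open), which would keep compound 3 at that limit. Compound 3 is expected to give about 26000 nM, within 12000 nM to 60000 nM.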

Compound 3, half-maximal effective concentration: > 26000 nM
Compound 3 was reported as a limit; the forecaster's own chance of this, stated with the estimate: 75%; the middle value lies on the limit itself.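

Going by these compounds alone, compound 3 stops at a limit of the assay, not a number, as do compound 1 and compound 2, so no step among them can be read in this assay: the limit of > 26000 nM in this assay, at which 3 of the 3 values shown sit. The compounds shown leave open whether exchanging pyridin-4-yl, 3-(isobutoxy)phenyl and 1H-indol-6-yl changes the concentration at which any effect appears.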